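The source may report more compounds than this note shows. Statements on the series, on what has been measured and on what is new or still open speak of the compounds shown alone.

In a physicochemical assay for solubility (on this read-out higher numbers stand for higher solubility and lower numbers for lower solubility), compound 1 `CNC(=O)c1cc(C(=O)NC)c(=O)n(Cc2ccccc2)c1` gives >= 118 ug/mL, which is a limit of the assay and not a number. Within the data shown here, compound 2 `CNC(=O)c1cc(C(=O)NCC(C)C)cn(Cc2ccccc2)c1=O` gives 43 ug/mL, the only true number so far. Compound 3 `CNC(=O)c1cc(C(=O)NC(C)C)cn(Cc2ccccc2)c1=O` differs from compound 2 as follows: isopropyl in place of isobutyl on an amide-type nitrogen. Among the measured compounds shown here, one measured step bears on this: an at least 2.7-fold lower number from compound 1 to compound 2 (0.43 log units; beyond the scatter), where the same amide-type nitrogen region gained isopropyl in place of hydrogen on a saturated chain carbon. The change to compound 3 shortens that chain and runs the opposite way, so a modest rise in this assay is expected, smaller than that one step and possibly within the scatter. The step expected is a 1.5-fold higher number from compound 2 to compound 3 (0.18 log units; within the scatter). For compound 3 the estimated value is 65 ug/mL, with an expected range of 32 ug/mL to 125 ug/mL.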

Compound 3, solubility: >= 136 ug/mL
Compound 3: no number, only a limit; the forecaster's own chance of this, stated with the estimate: 15%; middle value at least 2.0-fold (0.32 log units) away from the limit.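

Working from this assay, the smaller branched group on this amide-type nitrogen matters: isopropyl in place of isobutyl gives an at least 3.1-fold higher number from compound 2 to compound 3 (0.50 log units; beyond the scatter). As far as these compounds go, compound 3 gives >= 136 ug/mL, which is a limit of the assay and not a number, so the printed step is a minimum and its true size stays unknown. Among these compounds, until now the only readable step at this position was the fall of an at least 2.7-fold lower number from compound 1 to compound 2 (0.43 log units; beyond the scatter); with the new step, compound 2 with its isobutyl stands lower than both neighbours, and the change from isobutyl to isopropyl alone is enough to move the read-out beyond the scatter.

The step from compound 1 to compound 3 cannot be read, since both values are limits. From the compounds shown here alone, how a longer chain, a cyclopropyl group or an amine on this amide-type nitrogen would behave in this assay stays open, as does the true ceiling of compound 1 and compound 3.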